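A few compounds are considered here, and "the series" means these few. Any claim that something is new, unique, unknown or untested is made for them only; others in the source may bear on it.

Measured compounds:
compound 1 `COc1cccc(N2C(=O)COc3ccc(-c4cnc(Cl)c(NS(=O)(=O)c5ccc(F)cc5)c4)cc32)c1` — > 40000 nM
compound 2 `COc1ccc(N2C(=O)COc3ccc(-c4ccc(O)cc4)cc32)cc1` — 17300 nM
compound 3 `COc1ccc(N2C(=O)COc3ccc(-c4cnc(Cl)c(NS(=O)(=O)c5ccc(F)cc5)c4)cc32)cc1` — 36000 nM

The three were tested in a functional assay on MCF7 cells (Homo sapiens) for antiproliferative activity, read by MTT assay, with a stated time of 72 h; on this read-out higher numbers stand for weaker inhibition and lower numbers for stronger inhibition. Compound 1 gives only a limit there, > 40000 nM, a value at which the assay reports no number (the limit of > 40000 nM in this assay, at which 1 of the 3 values shown sits). Compound 3 gives 36000 nM in this assay. Compound 1 differs from compound 3 by 3-methoxyphenyl in place of 4-methoxyphenyl on an amide-type nitrogen in a ring, and this change produced an at least 1.1-fold higher number from compound 3 to compound 1 (0.04 log units; that floor lies within the scatter). Compound 2, which gives 17300 nM in this assay, differs from compound 3 in a way that is not broken down here; the two values show a lower number for compound 2 than for compound 3.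

Compound 4 `COc1cccc(N2C(=O)COc3ccc(-c4ccc(O)cc4)cc32)c1` has not yet been measured. It differs from compound 2 by 3-methoxyphenyl in place of 4-methoxyphenyl on an amide-type nitrogen in a ring, the same change as that from compound 3 to compound 1, at the same place. Compound 4 is expected to show a 1.3-fold higher number from compound 2 to compound 4 (0.10 log units; within the scatter) in this assay, a step estimated from an at least 1.1-fold higher number from compound 3 to compound 1 (0.04 log units; that floor lies within the scatter), whose floor lies within the scatter. Compound 4 is therefore expected to give about 22000 nM, with the estimate spanning 10000 nM to 45000 nM.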

Compound 4, half-maximal inhibitory concentration: > 40000 nM
Compound 4: a limit, no number; the forecaster's own chance of this, stated with the estimate: 20%; middle value at least 1.8-fold (0.25 log units) from the limit.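

In this assay compound 4 gives only a limit, > 40000 nM. Putting 3-methoxyphenyl in place of 4-methoxyphenyl on the amide-type nitrogen gives an at least 2.3-fold higher number from compound 2 to compound 4 (0.36 log units; beyond the scatter), so on the core of compound 2 the change clearly goes with weaker inhibition. The same change on the core of compound 3 has a floor that lies within the scatter, so the two cores show neither a step size that carries over from one to the other nor a real difference between them: the same change on two cores in this assay, an at least 1.1-fold higher number (0.04 log units; that floor lies within the scatter) from compound 3 to compound 1 and an at least 2.3-fold higher number (0.36 log units; beyond the scatter) from compound 2 to compound 4; the limit leaves it open whether they differ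

The compounds shown leave open how far compound 1 and compound 4 lie past that limit, and with it the true size of both steps: the limit of > 40000 nM in this assay, at which 2 of the 4 values shown sit. They also leave open whether a different group on the ring attached to the amide-type nitrogen, such as an amine, a carboxylic acid or a longer chain in place of methoxy, would give a lower number than compound 2 does.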